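The source may report more compounds than this note shows. Statements on the series, on what has been measured and on what is new or still open speak of the compounds shown alone.

Compound 1 `NS(=O)(=O)c1ccc(Nc2nc(N/N=C/c3ccc(C(F)(F)F)cc3)nc(Nc3ccccc3)n2)cc1`: 3310 nM
Compound 2 `Cc1nn(-c2ccccc2)cc1/C=N/Nc1nc(Nc2ccccc2)nc(Nc2ccc(S(N)(=O)=O)cc2)n1`: 3060 nM

In a functional assay on DU-145 cells (Homo sapiens) for inhibition, read by sulforhodamine B assay, with a stated time of 48 h (on this read-out higher numbers stand for weaker inhibition of growth and lower numbers for stronger inhibition of growth), compound 2 gives 3060 nM, and compound 1 gives 3310 nM; the two numbers lie within the scatter of each other. Compound 3 `NS(=O)(=O)c1ccc(Nc2nc(N/N=C/c3ccccn3)nc(Nc3ccccc3)n2)cc1` carries the change (pyridin-2-yl in place of 3-methyl-1-phenyl-1H-pyrazol-4-yl on a carbon with a double bond to nitrogen). Within the data shown here, the only measured step at this carbon, a 1.1-fold lower number from compound 1 to compound 2 (0.03 log units; within the scatter), exchanged one aromatic group for another without a shift beyond the scatter, so for compound 3 no step beyond the scatter is expected, as a 1.0-fold lower number from compound 2 to compound 3 (0.01 log units; within the scatter). Compound 3 is therefore estimated at 3000 nM, with a range from 1500 nM to 7000 nM.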

Compound 3, concentration for 50% growth inhibition: 850 nM
Compound 3: the middle estimate sits 3.5-fold (0.55 log units) above what was measured; measured number outside the range, below it.
By their numbers in this assay, from the lowest: compound 3; then compounds 2 and 1 (each within the scatter of the next).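

In this assay, the carbon with a double bond to nitrogen turns out to be a place where the group does change the number: pyridin-2-yl gives a 3.6-fold lower number from compound 2 to compound 3 (0.56 log units; beyond the scatter), and in place of 4-(trifluoromethyl)phenyl it gives a 3.9-fold lower number from compound 1 to compound 3 (0.59 log units; beyond the scatter). The two larger groups had stayed within the scatter of each other, so not every exchange of one aromatic group for another here is silent. Nothing available accounts for this step.

The compounds shown leave open whether the step goes with the ring nitrogen of pyridin-2-yl or with the smaller group as a whole. An unsubstituted phenyl group on this carbon would speak to that question.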